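Extending the methyl on a thiosemicarbazide

The source may hold more compounds than are shown below. What is called first, only, known or untested is meant among the compounds shown, and "the series" means these compounds.

Measured compounds:
compound 1 `CNC(=S)NNC(=O)Cn1c(=O)oc2ccc(C)cc21`: 71.6%
compound 2 `CCCn1c(Cn2c(=O)oc3ccc(C)cc32)n[nH]c1=S`: 44.3%

In a functional assay on the whole organism for inhibition, with Mus musculus as the target, read by paw edema, with a stated time of 180 min, at a dose of 200 mg/kg by the oral route (a lower number here means a weaker effect, a higher number a stronger effect of the compound at the dose given), compound 1 gives 71.6%, the higher of the two numbers; compound 2 gives 44.3%, a gap beyond the scatter. Compound 3 `CCCNC(=S)NNC(=O)Cn1c(=O)oc2ccc(C)cc21` is not yet measured. It differs from compound 1 by ethyl in place of hydrogen on a saturated chain carbon bound to an amide-type nitrogen. Going by the values given here, no measured pair shows this change, so its size can only be guessed. Compound 3 is expected to give a value close to that of compound 1, with a number 6.6 percentage points lower from compound 1 to compound 3 (within the scatter) as the estimated step, at most a small downward shift. The expected value for compound 3 is 65%, within 50% to 78%.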

Compound 3, a percentage reported as inhibition, in the whole organism at one dose (the size of the read-out at that dose, not a potency): 25.1%
For compound 3 the middle estimate is 39.9 percentage points above the measured one; measured number outside the range, below it.
By their numbers in this assay, from the lowest: compound 3; then compound 2; then compound 1.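

In this assay, the place on a saturated chain carbon bound to an amide-type nitrogen proves sensitive: going from methylamino to propylamino gives a number 46.5 percentage points lower from compound 1 to compound 3 (beyond the scatter). Going by these compounds alone, this is the first pair differing in this one place, so the earlier compounds gave no size for this change. Nothing measured here accounts for the drop.

On these data alone, whether a longer chain such as butyl would lower the number further remains open. So does how an ethylamino or a cyclopropylamino group would read at this place.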